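A few compounds are considered here, and "the series" means these few. Any claim that something is new, unique, unknown or untested is made for them only; others in the source may bear on it.

Three compounds built on one shared core were measured in a functional assay on MCF7 cells (Homo sapiens) for cytotoxicity, read by MTT assay, with a stated time of 48 h; on this read-out lower numbers stand for stronger inhibition and higher numbers for weaker inhibition. Compound 1, `O=C(CSc1nc2ccc(NC(=O)c3ccccc3)cc2s1)NCc1ccc(Cl)cc1`, gives 33700 nM in this assay. Compound 2, `CNC(=O)CSc1nc2ccc(NC(=O)c3ccccc3)cc2s1`, gives 34400 nM. Compound 3, `O=C(CSc1nc2ccc(NC(=O)c3ccccc3)cc2s1)NCc1ccccc1`, gives 35600 nM. The step of a 1.1-fold higher number from compound 1 to compound 3 (0.02 log units; within the scatter) and the step of a 1.0-fold higher number from compound 2 to compound 3 (0.01 log units; within the scatter) both lie within the scatter, so compound 3 sits on a par with the other two; none of the three can be told apart on these numbers.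

Compound 4, `COc1ccc(CNC(=O)CSc2nc3ccc(NC(=O)c4ccccc4)cc3s2)cc1`, differs from compound 3 by methoxy in place of hydrogen on an aromatic carbon, sitting on an aromatic carbon of a six-membered aromatic ring of carbon only, para to a large group. For the measured compounds named here, two measured steps bear on this change: a 1.1-fold higher number from compound 1 to compound 3 (0.02 log units; within the scatter), which removes a chloro from that same ring, and a 1.0-fold higher number from compound 2 to compound 3 (0.01 log units; within the scatter), which adds the whole phenyl ring in the first place. Going by the values given here, neither moved the number beyond the scatter, and no measured step anywhere in this set did. A methoxy on that ring is therefore not expected to matter, and the step to compound 4 is expected to be a 1.0-fold higher number from compound 3 to compound 4 (0.00 log units; within the scatter). Compound 4 is expected to give 36000 nM, within the range 18000 nM to 72000 nM.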

Compound 4, half-maximal inhibitory concentration: 21200 nM
Beside the measured number, compound 4's estimate is 1.7-fold (0.23 log units) above it, within the range that was stated.
By their numbers in this assay, from the lowest: compounds 4, 1, 2 and 3 (each within the scatter of the next).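

In this assay, a methoxy on this aromatic carbon gives a 1.7-fold lower number from compound 3 to compound 4 (0.23 log units; within the scatter) when it replaces hydrogen and a 1.6-fold lower number from compound 1 to compound 4 (0.20 log units; within the scatter) when it replaces chloro. Putting the whole 4-methoxyphenyl in place of hydrogen on the saturated chain carbon gives a 1.6-fold lower number from compound 2 to compound 4 (0.21 log units; within the scatter) as well. These steps are wider than the earlier ones, yet hydrogen, chloro and methoxy at this place still cannot be told apart, so the position now holds an oxygen-linked group as well as a halogen without a readable change.

No measurement shown here offers an explanation for these numbers. From the compounds shown here alone, whether an amine or a carboxylic acid on this same aromatic carbon, or a longer chain in place of the methoxy, would give a step beyond the scatter remains open.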